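This account rests on a few compounds, and the source may have more. Where it says the series, first, only, none or still open, it means among the compounds named here.

Of the compounds shown here, two built on one shared core have been tested in a functional assay on SR cells (Homo sapiens) for inhibition, read by sulforhodamine B assay, with a stated time of 48 h, tested at 10 uM; on this read-out lower numbers stand for less inhibition and higher numbers for more inhibition at the one concentration tested (going by the name of the read-out). Compound 1 `c1csc(-c2cn3ccnc3c(-c3ccc4ncn(C5CCCCC5)c4c3)n2)c1` carries a thiophene ring on the core; in this assay compound 1 gives 27.2%. Compound 2 `CCc1ccc(-c2cn3ccnc3c(-c3ccc4ncn(Cc5ccccc5)c4c3)n2)cc1` gives 49.9% in this assay, the higher of the two numbers, and compound 1 lies a step below it that goes beyond the usual scatter.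

Compound 3 `Cc1cccc(-c2cn3ccnc3c(-c3ccc4ncn(Cc5ccccc5)c4c3)n2)c1` has not yet been measured. It differs from compound 2 in a single place on an aromatic carbon of the core: 3-methylphenyl in place of 4-ethylphenyl on an aromatic carbon. Within the data shown here, no pair of measured compounds shows a change of this kind, so the size of the step in this assay can only be guessed. The expectation is a small step, one that may well stay within the scatter, a number 7.9 percentage points lower from compound 2 to compound 3 (within the scatter). Compound 3 is therefore estimated to give 42% in this assay, with a likely range from 25% to 60%.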

Compound 3, a percentage reported as inhibition, at one concentration (the size of the read-out at that concentration, not a potency): 11%
Compound 3: the middle estimate sits 31 percentage points above what was measured; measured number below the stated range.
By their numbers in this assay, from the lowest: compound 3; then compound 1; then compound 2.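

In this assay, 3-methylphenyl in place of 4-ethylphenyl on this aromatic carbon of the shared core brings a number 38.9 percentage points lower from compound 2 to compound 3 (beyond the scatter), so the read-out at this position depends strongly on which substituted phenyl group it carries, even though both groups are carbon-only aromatic rings without hydrogen-bond donors or acceptors. Among these compounds, this is also the first pair differing in one place, and so the first step that can be read directly. Nothing available here explains why the step is so large.

The change alters both the length of the alkyl chain and its place on the phenyl ring, and these two compounds cannot separate those effects. As far as these compounds go, it remains open how 4-methylphenyl or 3-ethylphenyl would read here, and how a phenyl ring carrying an amine or a carboxylic acid would behave.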